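Second chloro on the benzyl group: compound 3 in the series

A few compounds are considered here, and "the series" means these few. Any claim that something is new, unique, unknown or untested is made for them only; others in the source may bear on it.

Compound 1 `O=C(OCC(O)CO)c1nn(Cc2ccc(Cl)cc2)c2ccccc12` gives 503 mg/kg in a functional assay on the whole organism (Testis, strain Long-Evans) with Rattus norvegicus as the target, with a stated time of 5 days; on this read-out higher numbers stand for an effect only at larger amounts of compound and lower numbers for an effect already at smaller amounts. Compound 2 `O=C(OCC(O)CO)c1nn(Cc2ccccc2Cl)c2ccccc12`, in which the ring chloro sits in the 2-position instead of the 4-position, gives 503 mg/kg in this assay; the step of no change at the digits printed from compound 1 to compound 2 (within the scatter) is within the scatter, so compound 2 stands level with compound 1 on the numbers available, with no other measured neighbour.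

Compound 3 `O=C(OCC(O)CO)c1nn(Cc2ccc(Cl)cc2Cl)c2ccccc12` is the next step from compound 2: chloro in place of hydrogen on an aromatic carbon. Within the data shown here, the only measured step, from compound 1 to compound 2, moves the chloro around the ring without changing the read-out; no measured step adds a second chloro. Given that the position of one chloro left the number unchanged, the expectation for compound 3 is no step beyond the scatter, no change at the digits printed from compound 2 to compound 3 (within the scatter). Compound 3 is therefore estimated at 503 mg/kg in this assay, expected to lie between 250 mg/kg and 1000 mg/kg.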

Compound 3, minimum effective dose: 69 mg/kg
The estimate for compound 3 lay 7.3-fold (0.86 log units) above the measured number, outside the stated range (below it).
By their numbers in this assay, from the lowest: compound 3; then compounds 1 and 2 (each within the scatter of the next).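

In this assay the second chloro matters where moving the single chloro did not: on the 2-chlorophenyl group the added chloro gives a 7.3-fold lower number from compound 2 to compound 3 (0.86 log units; beyond the scatter), and on the 4-chlorophenyl group it gives a 7.3-fold lower number from compound 1 to compound 3 (0.86 log units; beyond the scatter). The 2,4-dichlorophenyl group therefore stands apart from both single-chloro groups, which sit level with each other, so the read-out here tracks the presence of both chloro groups and not the place of a single one. Nothing on hand accounts for this step.

Whether the lower number needs chloro itself remains open, since no other group, such as methyl, methoxy or an amine, stands at either ring position in the compounds shown. Also open, from the compounds shown here alone, is whether a carboxylic acid in place of the ester would keep the effect of the 2,4-dichlorophenyl group.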